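Phenyl for Propyl: What Compound 4 Might Show

The source may hold more compounds than are shown below. What is called first, only, known or untested is meant among the compounds shown, and "the series" means these compounds.

Of the compounds shown here, three have been measured in a functional assay on MDA-MB-231 cells (Homo sapiens) for cytotoxicity, read by sulforhodamine B assay, tested at 10 uM; a lower number here means less inhibition, a higher number more inhibition at the concentration tested (going by the name of the read-out). Compound 1 `O=c1[nH]c(=O)n([C@H]2C[C@H](O)[C@@H](CO)O2)cc1-c1cn(Cc2ccccc2)nn1` gives 103% in this assay. Compound 2 `CCCc1cc(-c2cn([C@H]3C[C@H](OC(C)=O)[C@@H](COC(C)=O)O3)c(=O)[nH]c2=O)on1` gives 102%, and compound 3 `CC(C)(C)c1ccc(-c2cc(-c3cn([C@H]4C[C@H](O)[C@@H](CO)O4)c(=O)[nH]c3=O)on2)cc1` gives 102%. Compound 2 is level with compound 3 at the digits shown, and its gap to compound 1 lies within the usual scatter, so all three numbers sit close together in this assay.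

Compound 4 `CC(=O)OC[C@H]1O[C@@H](n2cc(-c3cc(-c4ccccc4)no3)c(=O)[nH]c2=O)C[C@@H]1OC(C)=O` is the next compound to be measured. It differs from compound 2 by phenyl in place of propyl on an aromatic carbon; read one bond further out, the change runs from 3-propyl-1,2-oxazol-5-yl to 3-phenyl-1,2-oxazol-5-yl.

Among the measured compounds shown here, no pair of measured compounds separates this change on its own. Compound 3, which also carries a phenyl-type group and acetyl-free sugar, gives 102%, and on that basis the step of a number 2 percentage points lower from compound 2 to compound 4 (within the scatter) is expected to stay within the scatter, with no direction favoured. Compound 4 is therefore estimated at 100%, with a range from 88% to 108%.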

Compound 4, a percentage reported as inhibition, at one concentration (the size of the read-out at that concentration, not a potency): 95%
For compound 4 the middle estimate is 5 percentage points above the measured one; the measured number falls inside the stated range.
By their numbers in this assay, from the lowest: compounds 4, 2, 3 and 1 (each within the scatter of the next).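

Among the compounds shown here, the pair gives the first direct reading of this position: with phenyl in place of propyl on the aromatic carbon next to the ring nitrogen, this assay records a number 7 percentage points lower from compound 2 to compound 4 (within the scatter) and so shows no change that can be told from scatter. A six-membered aromatic ring of carbon only can therefore stand at this position in place of the open propyl chain, at least with the rest of compound 2 unchanged. Nothing measured beyond these numbers explains the result, so no cause can be given for it.

The compounds shown leave open whether an amine, a carboxylic acid or a longer chain on this same carbon would stay within the scatter of compound 2. They also leave open whether phenyl would read the same on a core with free hydroxyl groups on the sugar.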